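A few compounds are considered here, and "the series" means these few. Any claim that something is new, unique, unknown or untested is made for them only; others in the source may bear on it.

Compound 1, `CCCCCCC/N=C(\NC#N)Nc1cccnc1`, belongs to a small set of cyanoguanidines examined in a functional assay on the whole organism (blood, strain Wistar-Okamoto) with Rattus norvegicus as the target, with a stated time of 5 days; a lower number here means that less compound is needed, a higher number that more compound is needed for the effect. In this assay compound 1 gives only a limit of the measurement, > 50 mg/kg, and not a number. Its companion compound 2, `CCCCC(CC)C/N=C(\NC#N)Nc1cccnc1`, carries a branched chain on the same core. In this assay compound 2 likewise reaches only a limit, > 50 mg/kg. Among the measured compounds shown here, compound 1 therefore stands at the limit of > 50 mg/kg in this assay, at which 2 of the 2 values shown sit, so nothing in the two values sets one compound apart from the other, and no step between measured compounds can be given.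

The next compound, compound 3, is `N#CN/C(=N\CC1CCCO1)Nc1cccnc1`. It differs from compound 1 by oxolan-2-yl in place of hexyl on a saturated chain carbon bound to a double-bonded nitrogen. For the measured compounds named here, with both measured compounds sitting at the same limit, there is no measured step on which to build, and the step from compound 1 to compound 3 is expected to stay within the scatter, with a fair chance that this assay again reports only a limit for compound 3. On that basis compound 3 is estimated at 50 mg/kg in this assay, within a range from 20 mg/kg to 150 mg/kg. The expected step from compound 1 to compound 3 is a number no higher from compound 1 to compound 3 (the limit leaves the size open).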

Compound 3, minimum effective dose: 50 mg/kg
Estimate against measurement, compound 3: no gap at the digits printed; measured number inside the range.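

In this assay, among the compounds shown here, compound 3 gives 50 mg/kg, the only actual number among the values shown, so a minimum effective dose can be stated for this series for the first time. The change of hexyl to oxolan-2-yl on a saturated chain carbon bound to a double-bonded nitrogen, which puts an oxygen-bearing five-membered ring in place of an open chain, gives a number no higher from compound 1 to compound 3 (the limit leaves the size open), and it shows that this place accepts such a ring with a readable dose in this assay. The size of that step cannot be read, and the values shown remain close to a single point: the limit of > 50 mg/kg in this assay, at which 2 of the 3 values shown sit.

The compounds shown leave open whether the ring or its oxygen goes with the readable dose, a question that a cyclopentyl group at this place, a ring without the oxygen, would separate. They also leave open whether a morpholine ring or a primary amine on the chain would bring the dose in this assay clearly beyond the usual scatter of compound 3.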